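From propyl to 3-methylphenyl on an aromatic nitrogen

The source may hold more compounds than are shown below. What is called first, only, known or untested is meant among the compounds shown, and "the series" means these compounds.

Compound 1 `COc1cc(-c2nccn2C)cc(OC)c1OC`: > 100000 nM (a limit)
Compound 2 `CCCn1ccnc1-c1cc(OC)c(OC)c(OC)c1`: > 100000 nM (a limit)
Compound 3 `COc1cc(-c2nccn2S(=O)(=O)c2ccc(C)cc2)cc(OC)c1OC`: > 100000 nM (a limit)

All three were tested in a functional assay on T47D cells (Homo sapiens) for antiproliferative activity, read by MTT assay, with a stated time of 72 h; on this read-out lower numbers stand for stronger inhibition and higher numbers for weaker inhibition. Compound 2 has only a limit and no true number, and the series shares it: the limit of > 100000 nM in this assay, at which 3 of the 3 values shown sit. Compound 4 `COc1cc(-c2nccn2-c2cccc(C)c2)cc(OC)c1OC` alters one group: 3-methylphenyl in place of propyl on an aromatic nitrogen. Within the data shown here, the one measured step, a step that the two limits leave unreadable from compound 1 to compound 2, gives no size to build on. Compound 3 also carries a ring-bearing group on that nitrogen, yet it too reports only a limit. Only a modest move towards stronger inhibition is therefore expected, and possibly none. The expected step is an at least 2.0-fold lower number from compound 2 to compound 4 (0.30 log units; that floor lies within the scatter). For compound 4 the estimate is 50000 nM, with an expected range from 8000 nM to 200000 nM.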

Compound 4, half-maximal inhibitory concentration: 29300 nM
Beside the measured number, compound 4's estimate is 1.7-fold (0.23 log units) above it, and the stated range covers the measured number.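

Putting 3-methylphenyl in place of methyl or propyl on the aromatic nitrogen gives the series a true number in this assay, with an at least 3.4-fold lower number from compound 2 to compound 4 (0.53 log units; beyond the scatter) and an at least 3.4-fold lower number from compound 1 to compound 4 (0.53 log units; beyond the scatter). Both sizes are only minimums, because the comparison with compound 4 rests on limits: the limit of > 100000 nM in this assay, at which 3 of the 4 values shown sit.

Compound 3 also carries a ring-bearing group on that nitrogen and reports > 100000 nM, which is a limit, so a ring there is not enough on its own.

The compounds shown leave open whether the methyl on the phenyl ring matters. From the compounds shown here alone, how a plain phenyl, a benzyl or a pyridyl group on that nitrogen would compare also remains open.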